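Benzodioxinyl for Isopropoxyphenyl in a Cytotoxicity Series

The source may hold more compounds than are shown below. What is called first, only, known or untested is meant among the compounds shown, and "the series" means these compounds.

Three measured compounds share one core and differ at a single aromatic carbon: compound 1 `CC(C)N(Cc1cccc(OCCCCCC(=O)O)c1)C(=O)c1ccc(-c2cccc(N(C)C)c2)cc1`, compound 2 `CC(=O)c1cccc(-c2ccc(C(=O)N(Cc3cccc(OCCCCCC(=O)O)c3)C(C)C)cc2)c1` and compound 3 `CC(C)Oc1cccc(-c2ccc(C(=O)N(Cc3cccc(OCCCCCC(=O)O)c3)C(C)C)cc2)c1`. In an ADME assay on HEK293 cells (Homo sapiens) for cytotoxicity, read by CellTiter-Glo and resazurin assay, with a stated time of 72 h (on this read-out lower numbers stand for an effect already at smaller amounts and higher numbers for an effect only at larger amounts of compound), compound 1 gives > 26000 nM, which is a limit of the assay and not a number. Compound 2 likewise gives > 26000 nM in this assay, again a limit. Compound 3 gives > 26000 nM in this assay, also a limit. Compound 3 therefore stands at the limit of > 26000 nM in this assay, at which 3 of the 3 values shown sit, where the other two compounds also sit. The steps between these compounds cannot be sized: a step that the two limits leave unreadable from compound 1 to compound 2, a step that the two limits leave unreadable from compound 1 to compound 3 and a step that the two limits leave unreadable from compound 2 to compound 3.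

Compound 4 `CC(C)N(Cc1cccc(OCCCCCC(=O)O)c1)C(=O)c1ccc(-c2ccc3c(c2)OCCO3)cc1` departs from compound 3 by 2,3-dihydro-1,4-benzodioxin-6-yl in place of 3-isopropoxyphenyl on an aromatic carbon. Going by the values given here, no measured step bears on this change in a readable way, since all three values in this assay are limits. Among the compounds with values here, what the measured compounds show is only that changes at this aromatic carbon, across dimethylamino, acetyl and isopropoxy, have not brought any compound below the limit. On that basis compound 4 is expected to remain at the limit as well, so that the step that the limit leaves unreadable from compound 3 to compound 4 is expected to be none beyond the scatter. Compound 4 is estimated at 30000 nM, with a range from 15000 nM to 60000 nM.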

Compound 4, half-maximal effective concentration: > 21900 nM
Compound 4: only a limit was reported (the forecaster's own chance of this, stated with the estimate: 85%); the middle value is on the limit's open side.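

In this assay compound 4 gives > 21900 nM, which is a limit of the assay and not a number. Going by these compounds alone, compound 1, compound 2 and compound 3 also stand at limits, so no step from any of them to compound 4 can be read. The compounds shown leave open whether 2,3-dihydro-1,4-benzodioxin-6-yl and 3-isopropoxyphenyl differ at all in this assay.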